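Hydroxy to methoxy on the benzyl ring of compound 3

The compounds below may be only part of what the source reports. "The series", "measured", "known", "first", "only" and "open" are said of these compounds alone.

Compound 3 `Nc1ncnc2c1nc(NCc1ccc(-c3ccccc3)c(O)c1)n2[C@@H]1O[C@H](CO)[C@@H](O)[C@H]1O` carries a hydroxy group on the benzylic aromatic ring and in an assay on COS-7 cells for inhibition of sodium/nucleoside cotransporter 2 (Homo sapiens), read by scintillation counting (on this read-out higher numbers stand for weaker inhibition and lower numbers for stronger inhibition), compound 3 gives 1200 nM, the lowest number among the three measured compounds. Compound 1 `Nc1ncnc2c1nc(NCc1ccc(-c3ccccn3)cc1)n2[C@@H]1O[C@H](CO)[C@@H](O)[C@H]1O` stands nearest, and in this assay compound 1 gives 1500 nM, within the scatter of compound 3. Compound 2 `Nc1ncnc2c1nc(NCc1ccc(-c3ccncc3)cc1)n2[C@@H]1O[C@H](CO)[C@@H](O)[C@H]1O` stands furthest, and in this assay compound 2 gives 2700 nM, beyond the scatter of compound 3. Among the compounds with values here, the only measured step, a 1.8-fold higher number from compound 1 to compound 2 (0.26 log units; within the scatter), concerns the pyridyl ring and not the substituent on the benzylic ring, so no measured step bears directly on the present change.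

Compound 4 `COc1cc(CNc2nc3c(N)ncnc3n2[C@@H]2O[C@H](CO)[C@@H](O)[C@H]2O)ccc1-c1ccccc1` differs from compound 3 by methyl in place of hydrogen on an oxygen on an aromatic ring. Within the data shown here, with no comparable step measured, the expectation for compound 4 in this assay is a step of a 1.3-fold higher number from compound 3 to compound 4 (0.10 log units; within the scatter), not beyond the scatter in either direction. The estimate for compound 4 is therefore 1500 nM, with a range from 600 nM to 4000 nM.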

Compound 4, half-maximal inhibitory concentration: 1300 nM
Compound 4: middle estimate off by 1.2-fold (0.06 log units), on the high side, within the range that was stated.
By their numbers in this assay, from the lowest: compounds 3, 4, 1 and 2 (each within the scatter of the next, the first and the last beyond it).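

Within the data shown here, the step of a 1.1-fold higher number from compound 3 to compound 4 (0.03 log units; within the scatter) is the first reading in this assay of a change on this oxygen on an aromatic ring, and the two compounds stand within the scatter of each other. Hydroxy and methoxy are thus interchangeable here on this read-out, at least with the phenyl group that both compounds carry, so the hydrogen on this oxygen is not required for the level of inhibition seen in compound 3. No independent measurement bears on why the two compounds read alike.

As far as these compounds go, whether a longer chain such as ethoxy or propoxy on this oxygen would also stay within the scatter remains open. So does the outcome of putting an amine or a carboxylic acid in place of hydroxy, or of pairing methoxy with the pyridin-2-yl or pyridin-4-yl ring.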